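The source may report more compounds than this note shows. Statements on the series, on what has been measured and on what is new or still open speak of the compounds shown alone.

Measured so far:
compound 1 `Cc1ccc2oc(-c3ccc(Cl)cc3)cc(=O)c2c1` gives "not determined" (no result reported)
compound 2 `CN(C)Cc1ccc2oc(-c3ccc([N+](=O)[O-])cc3)cc(=O)c2c1` gives "not determined" (no result reported)
compound 3 `O=c1cc(-c2ccc([N+](=O)[O-])cc2)oc2c(CN3CCCCC3)cc(Cl)cc12` gives 8910 nM

Within the data shown here, in a functional assay on HepG2 cells (Homo sapiens) for cytotoxicity, read by MTT assay, with a stated time of 48 h (a lower number here means a stronger inhibitor, a higher number a weaker inhibitor), compound 3 gives 8910 nM as the only number, so it has no measured neighbour to be ranked against. Compound 4 `O=c1cc(-c2ccc([N+](=O)[O-])cc2)oc2c(Cn3ccnc3)cc(Cl)cc12` differs from compound 3 in one place 1H-imidazol-1-yl in place of piperidin-1-yl on a saturated chain carbon bound to an aromatic carbon with 1H-imidazol-1-yl in place of piperidin-1-yl on a saturated chain carbon bound to an aromatic carbon. Among the measured compounds shown here, no measured step exists to scale this change, so the expectation is weakly grounded. The estimated step of a 1.3-fold higher number from compound 3 to compound 4 (0.13 log units; within the scatter) is expected to stay within the usual scatter, with only a slight lean towards weaker inhibition. For compound 4 the estimate is 12000 nM in the middle, with 4000 nM to 40000 nM as the expected range.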

Compound 4, half-maximal inhibitory concentration: 2940 nM
Compound 4: middle estimate off by 4.1-fold (0.61 log units), on the high side, and the stated range ends above it.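

Among these compounds, exchanging piperidin-1-yl for 1H-imidazol-1-yl on this saturated chain carbon gives a 3.0-fold lower number from compound 3 to compound 4 (0.48 log units; beyond the scatter) in this assay and is the first sign that the read-out responds to the group at this position. The aromatic five-membered ring is accepted here without loss, though this rests on one pair. No supporting data explain the shift.

As far as these compounds go, whether the change follows from ring aromaticity, ring size or the added nitrogen stays open. Morpholin-4-yl, 1H-1,2,4-triazol-1-yl or a longer chain carrying the imidazole on this carbon would bear on that question.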